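The source may hold more compounds than are shown below. What is called first, only, known or untested is meant among the compounds shown, and "the series" means these compounds.

Working notes on a pentafluorophenylsulfonamide series. Of the compounds shown here, two have been tested. Compound 1 `O=S(=O)(Nc1ccc2[nH]ccc2c1)c1c(F)c(F)c(F)c(F)c1F` carries the sulfonamide on a bicyclic aromatic amine; in a functional assay on NCI/ADR-RES cells (Homo sapiens) for inhibition (on this read-out lower numbers stand for stronger inhibition of growth and higher numbers for weaker inhibition of growth), compound 1 gives 115 nM. Compound 2 `CN(C)c1ccc(NS(=O)(=O)c2c(F)c(F)c(F)c(F)c2F)cc1` carries it on a simple benzene ring bearing a dimethylamino group; in this assay compound 2 gives 96 nM. The gap between compound 2 and compound 1 is within the scatter, so the two sit at the same level as far as these numbers can tell, and no ordering is claimed.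

Compound 3 `COc1ccc(NS(=O)(=O)c2c(F)c(F)c(F)c(F)c2F)cc1` has not yet been measured. It differs from compound 2 in one place: methoxy in place of dimethylamino on an aromatic carbon. For the measured compounds named here, no measured pair in this set shows the size of such a step, so what follows is an expectation rather than a reading. Given that compound 1 and compound 2 already agree in this assay despite quite different amine portions, a step of a 1.6-fold higher number from compound 2 to compound 3 (0.19 log units; within the scatter) is expected, that is, little change, if anything a slightly higher number. Compound 3 is estimated at 150 nM, with a range from 60 nM to 400 nM.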

Compound 3, concentration for 50% growth inhibition: 58 nM
Beside the measured number, compound 3's estimate is 2.6-fold (0.41 log units) above it; the whole stated range lies above it.
By their numbers in this assay, from the lowest: compounds 3, 2 and 1 (each within the scatter of the next).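

At this position, on an aromatic carbon para to a large group, methoxy in place of dimethylamino gives a 1.7-fold lower number from compound 2 to compound 3 (0.22 log units; within the scatter) in this assay and provides the first measured size for a change at this place in the series. The two groups can therefore be exchanged here without a difference that these numbers can separate from the scatter, and neither group is marked out as required at this position. Nothing on hand bears on the reason for this result.

Still open, going by these compounds, is whether other groups at the same position, such as a chlorine atom, a carboxylic acid or a longer alkoxy chain, would stay at this level. Also open, on these data alone, is whether the agreement between compound 2 and compound 3 carries over to any read-out other than this assay.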